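Swapping halogenated rings on a sulfonamide nitrogen

The source may report more compounds than this note shows. Statements on the series, on what has been measured and on what is new or still open speak of the compounds shown alone.

Compound 2, `COc1ccc(S(=O)(=O)Nc2c(F)cc(Br)cc2F)cc1N1CCNCC1`, gives 158 nM in an assay on isolated protein for binding affinity to 5-hydroxytryptamine receptor 6 (Homo sapiens) (a higher number here means a weaker inhibitor, a lower number a stronger inhibitor), the highest of the two numbers at hand. Within the data shown here, its nearest neighbour is compound 1, `COc1ccc(S(=O)(=O)Nc2cc(Cl)cc(Cl)c2)cc1N1CCNCC1`, which gives 0.631 nM in this assay; the only step so far, a 250-fold higher number from compound 1 to compound 2 (2.40 log units; beyond the scatter), shows how strongly the ring on the sulfonamide nitrogen can move the number. Compound 3, `COc1ccc(S(=O)(=O)Nc2cc(Br)cc(Br)c2Br)cc1N1CCNCC1`, is the next member: 2,3,5-tribromophenyl in place of 4-bromo-2,6-difluorophenyl on a sulfonamide nitrogen. Among the measured compounds shown here, the only step that bears on this change is the one from compound 1 to compound 2, which was large. For the measured compounds named here, the 2,3,5-tribromophenyl of compound 3 resembles the 3,5-dichlorophenyl of compound 1 more than it resembles the 4-bromo-2,6-difluorophenyl of compound 2, so a lower number is expected, though with a wide range because only one step is available to judge by. The expected change is a 16-fold lower number from compound 2 to compound 3 (1.20 log units; beyond the scatter). Compound 3 is therefore estimated at 10 nM, within a range from 1 nM to 100 nM.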

Compound 3, inhibition constant: 2.51 nM
Compound 3: middle estimate off by 4.0-fold (0.60 log units), on the high side; the measured number falls inside the stated range.
By their numbers in this assay, from the lowest: compound 1; then compound 3; then compound 2.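

Replacing the ring on the sulfonamide nitrogen of compound 2 with 2,3,5-tribromophenyl undoes most of the earlier loss in this assay: the change gives a 63-fold lower number from compound 2 to compound 3 (1.80 log units; beyond the scatter) and, measured against the 3,5-dichlorophenyl ring, a 4.0-fold higher number from compound 1 to compound 3 (0.60 log units; beyond the scatter). This place therefore accepts a ring with three bromines, and the two swapped rings cannot be told apart by their counts of heavy atoms or hydrogen-bond donors and acceptors, yet their numbers differ widely. The data available give no explanation for this difference.

Compound 2 is the only one of the three carrying fluorine, but it also differs in where its halogens sit, so these compounds cannot separate those two features. Going by these compounds, how a ring bearing an amine or a carboxylic acid would behave here also remains open.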